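This account rests on a few compounds, and the source may have more. Where it says the series, first, only, none or still open, it means among the compounds named here.

Compound 1 `Nc1nc(Cl)c2ncn(Cc3ccccc3CCl)c2n1` carries an amino group on its shared core, and in a functional assay on ACHN cells (Homo sapiens) for cytotoxicity, read by sulforhodamine B assay, with a stated time of 48 h (a higher number here means a weaker inhibitor of growth, a lower number a stronger inhibitor of growth), compound 1 gives 21900 nM. Going by the values given here, of the two compounds measured so far, this is the highest number, so compound 1 is the weaker of the pair. Among the compounds with values here, the companion, compound 2 `ClCc1ccccc1Cn1cnc2ncnc(Cl)c21`, lacks that amino group altogether, and in this assay compound 2 gives 4260 nM; the two values stand apart by more than the usual scatter, though no single-point step connects these two structures.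

Compound 3 `ClCc1ccccc1Cn1cnc2c(Cl)nc(Cl)nc21` differs from compound 1 in one place: chloro in place of amino on an aromatic carbon. The chloro enters on an aromatic carbon of a six-membered aromatic ring with two nitrogens, between two ring nitrogen atoms, meta to a chloro group. Since the amino that leaves is the group absent from compound 2, and compound 2 gives 4260 nM, the expectation is that compound 3 lands nearer that value, a moderate drop in number rather than no change. The step expected from compound 1 to compound 3 in this assay is a 3.4-fold lower number from compound 1 to compound 3 (0.53 log units; beyond the scatter). Compound 3 is estimated at 6500 nM, within a range from 2000 nM to 20000 nM.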

Compound 3, concentration for total growth inhibition: 1620 nM
Estimate against measurement, compound 3: 4.0-fold (0.60 log units) above; the whole stated range lies above it.
By their numbers in this assay, from the lowest: compound 3; then compound 2; then compound 1.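

In this assay, putting chloro in place of amino on this aromatic carbon gives a 14-fold lower number from compound 1 to compound 3 (1.13 log units; beyond the scatter), a large step. Going by these compounds alone, the earlier pair had no single-place step, so this is the first direct sign that the group at this carbon, between two ring nitrogen atoms, strongly affects the number. The printed values add a further point: compound 2, which has neither group here, gives 4260 nM and compound 3 gives 1620 nM, so lacking the amino does not by itself bring the number down to that of the chloro compound, and nothing here explains why the chloro compound stands lowest.

The compounds shown leave open whether chloro is special at this carbon or whether another group, such as bromo, methoxy, methyl or a larger amine like dimethylamino, would give a similar number. They also leave open whether the same swap would have a step of this size if the chloro group at the other ring carbon or the chloromethyl group on the benzene ring were replaced.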